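The source may hold more compounds than are shown below. What is called first, only, known or untested is meant among the compounds shown, and "the series" means these compounds.

Compound 1 `Cn1c(-c2ccc(NC(=O)CN3CCN(c4ccccc4)CC3)cc2)nc(-c2ccccc2)c1-c1ccccc1` gives 12.1% in a functional assay on MCF7 cells (Homo sapiens) for cytotoxicity, read by MTT assay, with a stated time of 24 h, tested at 0.64 ug/mL; a lower number here means a weaker effect, a higher number a stronger effect of the compound at the concentration tested. Compound 2 `Cn1c(-c2ccc(NC(=O)CN3CCN(Cc4ccccc4)CC3)cc2)nc(-c2ccccc2)c1-c1ccccc1` gives 7.2% in this assay, and the step of a number 4.9 percentage points lower from compound 1 to compound 2 (within the scatter) leaves the two within the scatter of each other, so compound 2 sits alongside compound 1 rather than apart from it. Compound 3 `Cn1c(-c2ccc(NC(=O)CN3CCN(Cc4ccc(Cl)cc4)CC3)cc2)nc(-c2ccccc2)c1-c1ccccc1` differs from compound 2 by chloro in place of hydrogen on an aromatic carbon. Among the measured compounds shown here, no measured step touches this change: the only step, a number 4.9 percentage points lower from compound 1 to compound 2 (within the scatter), concerns benzyl in place of phenyl on the amine nitrogen in the ring, not a chloro. With nothing pointing either way, compound 3 is expected to show a step of a number 1.8 percentage points higher from compound 2 to compound 3 (within the scatter) in this assay, not beyond the scatter. Compound 3 is therefore estimated at 9%, within 0% to 22%.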

Compound 3, a percentage reported as activity, at one concentration (the size of the read-out at that concentration, not a potency): 4.8%
Compound 3: middle estimate off by 4.2 percentage points, on the high side; the measured number falls inside the stated range.
By their numbers in this assay, from the lowest: compounds 3, 2 and 1 (each within the scatter of the next).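

Chloro in place of hydrogen on an aromatic carbon, para to a large group, gives a number 2.4 percentage points lower from compound 2 to compound 3 (within the scatter) in this assay, so this substitution on the benzyl ring leaves compound 3 alongside compound 2. Even 4-chlorobenzyl in place of phenyl on the amine nitrogen gives only a number 7.3 percentage points lower from compound 1 to compound 3 (within the scatter), so neither change on that nitrogen has yet moved the read-out beyond the scatter. No measurement offers an explanation for these numbers. As far as these compounds go, it remains open whether a methoxy group or a carboxylic acid at this ring position, or a longer chain in place of benzyl, would do so.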